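The source may hold more compounds than are shown below. What is called first, only, known or untested is meant among the compounds shown, and "the series" means these compounds.

Values in an ADME assay on HepG2 2.2.15 cells (Homo sapiens) for cytotoxicity; a higher number here means that more compound is tolerated, a lower number that less compound is tolerated:
- Compound 1 `O=C(O)CCCC(=O)OCCc1c(-c2ccccc2Cl)c2cc(Cl)ccc2[nH]c1=O`: 110000 nM
- Compound 2 `CC12CCC(C(=O)OCCc3c(-c4ccccc4Cl)c4cc(Cl)ccc4[nH]c3=O)(OC1=O)C2(C)C`: > 1800000 nM (a limit)
- Compound 3 `COc1ccc(/C=C/C(=O)OCCc2c(-c3ccccc3Cl)c3cc(Cl)ccc3[nH]c2=O)cc1`: > 1200000 nM (a limit)

For compound 3, the reading > 1200000 nM is a limit and not a number. Compound 2 also has only a limit, so compound 1 is the only one of the three with a measured number. Two large steps show this gap: an at least 10-fold higher number from compound 1 to compound 3 (1.03 log units; beyond the scatter), and an at least 16-fold higher number from compound 1 to compound 2 (1.21 log units; beyond the scatter). Between the two limits, the result is a step that the two limits leave unreadable from compound 2 to compound 3.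

Compound 4 `C/C=C/C(=O)OCCc1c(-c2ccccc2Cl)c2cc(Cl)ccc2[nH]c1=O` carries methyl in place of 4-methoxyphenyl on a double-bonded chain carbon bound to a double-bonded chain carbon. For the measured compounds named here, no measured step tests this change directly. Both large steps, however, start from compound 1 and remove its 3-carboxypropyl, a group that compound 4 also lacks. No step beyond the scatter is therefore expected in this assay, and no direction can be stated with confidence. The step expected is an at least 1.2-fold lower number from compound 3 to compound 4 (0.07 log units; that floor lies within the scatter). For compound 4, the estimated value is 1000000 nM, with an expected range from 250000 nM to 2500000 nM.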

Compound 4, half-maximal cytotoxic concentration: 30000 nM
Beside the measured number, compound 4's estimate is 33-fold (1.52 log units) above it; measured number below the stated range.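

On a double-bonded chain carbon bound to a double-bonded chain carbon, the group proves decisive in this assay: methyl in place of 4-methoxyphenyl gives an at least 40-fold lower number from compound 3 to compound 4 (1.60 log units; beyond the scatter) and so ends the high tolerance seen earlier. Losing 3-carboxypropyl is therefore not enough for a rise, since prop-1-en-1-yl on the carbonyl carbon gives a 3.7-fold lower number from compound 1 to compound 4 (0.56 log units; beyond the scatter), the reverse of the earlier direction, and the comparison with the larger group gives an at least 60-fold lower number from compound 2 to compound 4 (1.77 log units; beyond the scatter). The steps from compound 2 and compound 3 start from limits and not from numbers, and nothing shown gives a cause for the fall.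

As far as these compounds go, only 4-methoxyphenyl and methyl are compared at this place, so it stays open whether the aromatic ring alone carries the tolerance. From the compounds shown here alone, how an unsubstituted phenyl, an amine or a longer chain would read there also remains open.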